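Working notes: amine nitrogen substituents, three measured, one pending

A few compounds are considered here, and "the series" means these few. Any claim that something is new, unique, unknown or untested is made for them only; others in the source may bear on it.

Measured so far in a functional assay on HeLa cells (Homo sapiens) for cytotoxicity, read by MTT assay, with a stated time of 48 h; on this read-out higher numbers stand for weaker inhibition and lower numbers for stronger inhibition:
Compound 1 `COc1ccc(N/C(CCNC2=CC(=O)c3ccccc3C2=O)=N\S(=O)(=O)c2ccc(C)cc2)cc1OC` gives 14500 nM.
Compound 2 `Cc1ccc(S(=O)(=O)/N=C(/CCNC2=CC(=O)c3ccccc3C2=O)Nc2ccc(Cl)cc2Cl)cc1` gives 20500 nM.
Compound 3 `Cc1ccc(S(=O)(=O)/N=C(/CCNC2=CC(=O)c3ccccc3C2=O)NC(C)C)cc1` gives 30200 nM.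

Compound 3 holds the highest number of the three; its gap to compound 2 stays within the scatter (a 1.5-fold higher number from compound 2 to compound 3 (0.17 log units; within the scatter)), while the step of a 2.1-fold higher number from compound 1 to compound 3 (0.32 log units; beyond the scatter) reaches beyond it. Compound 4 `Cc1ccc(S(=O)(=O)/N=C(\N)CCNC2=CC(=O)c3ccccc3C2=O)cc1` differs from compound 3 by hydrogen in place of isopropyl on an amine nitrogen. The steps of a 2.1-fold higher number from compound 1 to compound 3 (0.32 log units; beyond the scatter) and a 1.5-fold higher number from compound 2 to compound 3 (0.17 log units; within the scatter) both trimmed the group on this nitrogen and both moved the number upward, one of them modestly. Removing the last carbons there is therefore expected to give a further small rise, a 1.4-fold higher number from compound 3 to compound 4 (0.14 log units; within the scatter), likely near the edge of the scatter. Compound 4 is estimated at 42000 nM, within 20000 nM to 90000 nM.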

Compound 4, half-maximal inhibitory concentration: 24600 nM
Compound 4: the middle estimate sits 1.7-fold (0.23 log units) above what was measured; low and high end bracket the measured number.
By their numbers in this assay, from the lowest: compounds 1, 2, 4 and 3 (each within the scatter of the next, the first and the last beyond it).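

With hydrogen on this amine nitrogen, the number in this assay cannot be told apart from the isopropyl compound (a 1.2-fold lower number from compound 3 to compound 4 (0.09 log units; within the scatter)), the 2,4-dichlorophenyl compound (a 1.2-fold higher number from compound 2 to compound 4 (0.08 log units; within the scatter)) or the 3,4-dimethoxyphenyl compound (a 1.7-fold higher number from compound 1 to compound 4 (0.23 log units; within the scatter)). The upward drift seen as the group was trimmed therefore does not continue to the bare amino compound, and only the gap between compound 1 and compound 3 lies beyond the scatter. No available evidence bears on this result.

Open, going by these compounds, is whether a carboxylic acid or a longer alkyl chain on this nitrogen would shift the number beyond the scatter.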